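The compounds below may be only part of what the source reports. "The series", "measured", "known", "first", "only" and "open" are said of these compounds alone.

Series measured in a functional assay on PC-3 cells (Homo sapiens) for inhibition, read by sulforhodamine B assay, with a stated time of 48 h, tested at 50 uM; a lower number here means less inhibition of growth, a higher number more inhibition of growth at the concentration tested:

- compound 1 `COc1cc(/C=C/C(=O)/C=C/c2cccc3ccccc23)ccc1OCc1cn(CCCOc2cc(=O)oc3ccccc23)nn1`: 8%
- compound 2 `COc1cc(/C=C/C(=O)/C=C/c2ccco2)ccc1OCc1cn(CCCOc2cc(=O)oc3ccccc23)nn1`: "not active" (no number reported)
- compound 3 `COc1ccc(/C=C/C(=O)/C=C/c2ccc(OCc3cn(CCCOc4cc(=O)oc5ccccc45)nn3)c(OC)c2)cc1OC`: 9%

For the measured compounds named here, only two of the three compounds carry a number. Compound 3, at 9%, cannot be separated from compound 1, since the gap is a number 1 percentage points higher from compound 1 to compound 3 (within the scatter). Compound 2 has no number to compare.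

The next compound is compound 4 `COc1cc(/C=C/C(=O)/C=C/c2cccs2)ccc1OCc1cn(CCCOc2cc(=O)oc3ccccc23)nn1`, still unmeasured in this assay. Its change from compound 3 is thiophen-2-yl in place of 3,4-dimethoxyphenyl on a double-bonded chain carbon bound to a double-bonded chain carbon. Going by the values given here, the core is untouched, so only this one group differs.

Two observations bear on the change, and both concern the same place on the chain. Among the compounds with values here, the one measured step there, a number 1 percentage points higher from compound 1 to compound 3 (within the scatter), stays within the scatter, so swapping one group for another at this place has not yet moved the number measurably. Compound 2, which also differs at this place, is reported as "not active" (no number reported), so a result without a number remains possible for compound 4. Within the data shown here, the data hold no step from a number to a thiophen-2-yl compound, which keeps the range wide.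

The expected change is small, with a number 3 percentage points lower from compound 3 to compound 4 (within the scatter) estimated to stay within the scatter. For compound 4 the estimated value is 6%, with an expected range from 0% to 14%.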

Compound 4, percent growth inhibition at one concentration: "not active" (no number reported)
The entry for compound 4 holds no number, and the estimate cannot be compared.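

In this assay, for the compounds shown here, compound 4 gives "not active" (no number reported) and compound 3 gives 9%, so no step between compound 3 and compound 4 can be read. No available evidence bears on this result. The compounds shown leave open whether any group at this place on the chain changes growth inhibition beyond the scatter.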